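Varying the aryl group on the unsaturated ring carbon

This account rests on a few compounds, and the source may have more. Where it says the series, first, only, none or still open, it means among the compounds named here.

Compound 1, `C[C@@H](O[C@H]1CN2C(=O)C=C(c3ccc(CO)cc3)CC2[C@@H]1c1ccc(F)cc1)c1cc(C(F)(F)F)cc(C(F)(F)F)c1`, gives 23 nM in an assay on CHO cells for displacement of a labelled ligand from Substance-P receptor (Homo sapiens), in the presence of a further agent that is not named here; a higher number here means a weaker inhibitor, a lower number a stronger inhibitor.
Compound 2, `C[C@@H](O[C@H]1CN2C(=O)C=C(c3ccncc3)CC2[C@@H]1c1ccc(F)cc1)c1cc(C(F)(F)F)cc(C(F)(F)F)c1`, gives 8.1 nM.
Compound 3, `Cc1cc(C2=CC(=O)N3C[C@H](O[C@H](C)c4cc(C(F)(F)F)cc(C(F)(F)F)c4)[C@@H](c4ccc(F)cc4)C3C2)ccn1`, gives 34 nM.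

Among these three numbers compound 1 stands second highest: its nearest neighbour is compound 3, from which it is separated by a 1.5-fold higher number from compound 1 to compound 3 (0.17 log units; within the scatter), and its furthest is compound 2, reached by a 2.8-fold lower number from compound 1 to compound 2 (0.45 log units; beyond the scatter). The unmeasured compound 4, `C[C@@H](O[C@H]1CN2C(=O)C=C(c3ccc[n+]([O-])c3)CC2[C@@H]1c1ccc(F)cc1)c1cc(C(F)(F)F)cc(C(F)(F)F)c1`, differs from compound 1 in one place: a group of 7 heavy atoms (5 carbon, 1 nitrogen, 1 oxygen; one six-membered aromatic ring with 1 hetero atom) in place of a group of 8 heavy atoms (7 carbon, 1 oxygen; one six-membered aromatic ring of carbon only), on a double-bonded ring carbon. Among the measured compounds shown here, the change keeps a six-membered aromatic ring on the same double-bonded ring carbon, so the steps that bear on it are the two that swap that ring in compound 1 for a ring with 1 hetero atom. Of those, the move to compound 2 was modest and beyond the scatter, while the move to compound 3 stayed within it. For the measured compounds named here, no measured step covers a ring carrying both a nitrogen and an oxygen, so the expectation rests on those two steps alone. Compound 4 is therefore expected to give a number in this assay close to that of compound 1, with the step of a 1.4-fold lower number from compound 1 to compound 4 (0.16 log units; within the scatter) lying at most at the edge of the scatter. The estimate for compound 4 is 16 nM, between 5 nM and 50 nM.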

Compound 4, half-maximal inhibitory concentration: 2.3 nM
For compound 4 the middle estimate is 7.0-fold (0.84 log units) above the measured one; measured number below the stated range.
By their numbers in this assay, from the lowest: compound 4; then compound 2; then compounds 1 and 3 (each within the scatter of the next).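

The ring carrying both a nitrogen and an oxygen makes compound 4 the strongest inhibitor of the four in this assay, with a 10-fold lower number from compound 1 to compound 4 (1.00 log units; beyond the scatter) and a 3.5-fold lower number from compound 2 to compound 4 (0.55 log units; beyond the scatter), so this double-bonded ring carbon tolerates more than the earlier steps had shown and can give a clear gain over both the 4-(hydroxymethyl)phenyl and the pyridin-4-yl groups. Among the compounds shown here, the widest gap at this position now appears against the methylated pyridine, a 15-fold lower number from compound 3 to compound 4 (1.17 log units; beyond the scatter), and the range of numbers set by changing this one group alone is larger than the earlier compounds suggested. Nothing available here accounts for the size of this gain.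

The group in compound 4 differs from the pyridin-4-yl of compound 2 both in bearing the oxygen and in where the nitrogen stands in the ring, so the compounds shown leave open which of the two carries the gain, and a plain pyridin-3-yl group would separate them. They also leave open how a six-membered aromatic ring bearing an amine or a carboxylic acid would fare on this same carbon.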